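The source may hold more compounds than are shown below. What is called first, only, known or untested is meant among the compounds shown, and "the series" means these compounds.

Measured so far:
compound 1, `C/C(=C/c1ccc(Cc2cccnc2)n1C(C)C)C(=O)O` — 2100 nM
compound 2, `C/C(=C\c1cc(Cn2ccnc2)n(C)c1)C(=O)O` — 1600 nM

In a functional assay on microsomes from aorta for inhibition of Thromboxane-A synthase (Homo sapiens), in the presence of a further agent that is not named here (on this read-out higher numbers stand for weaker inhibition and lower numbers for stronger inhibition), compound 2 gives 1600 nM, the lower of the two numbers available. Compound 1 gives 2100 nM in this assay; the gap between compound 2 and compound 1 lies within the scatter, so no order between the two is claimed, and neither is called the stronger inhibitor.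

Compound 3, `Cn1cc(/C=C/C(=O)O)cc1Cn1ccnc1`, is not yet measured. It differs from compound 2 in one place: 2-carboxyethenyl in place of 2-carboxyprop-1-en-1-yl on an aromatic carbon. Among the measured compounds shown here, no pair of measured compounds shows a step of this kind, so there is nothing in hand to calibrate it; the change is small in size and leaves donor and acceptor count unchanged.

The step from compound 2 to compound 3 in this assay is expected to be a 1.4-fold higher number from compound 2 to compound 3 (0.14 log units; within the scatter), a slight move toward weaker inhibition, not clearly beyond the scatter.

For compound 3 in this assay the estimate is 2200 nM, with a range from 800 nM to 6500 nM.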

Compound 3, half-maximal inhibitory concentration: 4600 nM
For compound 3 the middle estimate is 2.1-fold (0.32 log units) below the measured one; low and high end bracket the measured number.
By their numbers in this assay, from the lowest: compounds 2 and 1 (each within the scatter of the next); then compound 3.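

In this assay, this position now has its first readable step: 2-carboxyethenyl in place of 2-carboxyprop-1-en-1-yl on an aromatic carbon gives a 2.9-fold higher number from compound 2 to compound 3 (0.46 log units; beyond the scatter) and so a modest move toward weaker inhibition, beyond the scatter. Among the compounds shown here, the earlier compounds offered no step at all, so this is the first sign that the group here matters in this assay, even for a change from 6 heavy atoms to 5 with donor and acceptor counts unchanged. Nothing in hand accounts for the shift.

For the compounds shown here, with only this one step, it stays open whether a longer chain, such as 2-carboxybut-1-en-1-yl, would move the number the other way. On these data alone, it is equally open whether a methyl ester in place of the carboxylic acid would be tolerated at this position.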